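The compounds below may be only part of what the source reports. "The series", "measured", "known", "first", "only" and "open" are said of these compounds alone.

Measured in a functional assay on KM12 cells (Homo sapiens) for inhibition, read by sulforhodamine B assay, with a stated time of 48 h; on this read-out higher numbers stand for weaker inhibition of growth and lower numbers for stronger inhibition of growth:
- compound 1 `COc1cc(-c2nn(-c3cccc(NC(=O)Nc4ccc(Cl)c(Cl)c4)c3)cc2-c2ccncc2)ccc1Cl`: 2770 nM
- compound 2 `COc1cc(-c2nn(-c3cccc(NC(=O)Nc4cccc(C(F)(F)F)c4)c3)cc2-c2ccncc2)ccc1Cl`: 1980 nM
- compound 3 `COc1cc(-c2nn(-c3cccc(NC(=O)c4ccc(Cl)c(C(F)(F)F)c4)c3)cc2-c2ccncc2)ccc1Cl`: > 32500 nM, a limit and not a number

Compound 3 stands at the limit of > 32500 nM in this assay, at which 1 of the 3 values shown sits. The numbers leading to it show large steps: an at least 11-fold higher number from compound 1 to compound 3 (1.06 log units; beyond the scatter), and an at least 16-fold higher number from compound 2 to compound 3 (1.21 log units; beyond the scatter).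

Compound 4 `COc1cc(-c2nn(-c3cccc(NC(=O)c4ccccc4)c3)cc2-c2ccncc2)ccc1Cl` keeps everything in compound 3 except the group on the carbonyl carbon, where phenyl takes the place of 4-chloro-3-(trifluoromethyl)phenyl: phenyl in place of 4-chloro-3-(trifluoromethyl)phenyl on a carbonyl carbon.

The two large steps bear on this change only indirectly. Each removes the amino link on the carbonyl carbon as well as changing the phenyl group, so they show where compound 3 stands, not what a change of the phenyl group alone does when that link is absent. The nearest guide is a change of the substituted phenyl group alone, a 1.4-fold lower number from compound 1 to compound 2 (0.15 log units; within the scatter). Among the compounds with values here, that is a single example with the amino link still present, and no measured step goes to plain phenyl.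

Going by that small step, no change beyond the scatter is expected in this assay, and the assay may well report only a limit again. The expected step is a step that the limit leaves unreadable from compound 3 to compound 4. For compound 4 the estimated value is 35000 nM, with an expected range from 15000 nM to 70000 nM.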

Compound 4, concentration for total growth inhibition: > 100000 nM
Compound 4 ended at the assay's limit (the forecaster's own chance of this, stated with the estimate: 75%); at least 2.8-fold (0.45 log units) between middle value and limit.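

In this assay compound 4 also ends at a limit and not at a number: the limit of > 100000 nM in this assay, at which 1 of the 4 values shown sits. Compound 3 and compound 4 both stand at limits, so the step between them cannot be read, and these two compounds cannot show whether removing the chlorine and the trifluoromethyl group from the phenyl ring changes growth inhibition. What compound 4 adds is a second compound without the amino link on the carbonyl carbon that sits far from the compounds that keep this link, with an at least 50-fold higher number from compound 2 to compound 4 (1.70 log units; beyond the scatter) and an at least 36-fold higher number from compound 1 to compound 4 (1.55 log units; beyond the scatter), so weak growth inhibition without the link appears with both a substituted and a plain phenyl group.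

Each of these large steps removes the amino link and changes the phenyl group at once, which leaves open how much belongs to the link alone; plain phenylamino on the carbonyl carbon would separate the two changes. Also open, on these data alone, is how the carbonyl carbon would fare with a methyl group, a longer alkyl chain or a phenyl ring bearing an amine in place of these groups.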